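Swapping the urea arm of compound 1 for an ester chain

A few compounds are considered here, and "the series" means these few. Any claim that something is new, unique, unknown or untested is made for them only; others in the source may bear on it.

Measured compounds:
compound 1, `CCOC(=O)CNC(=O)NC1=CS(=O)(=O)O[C@@]12[C@@H](CO[Si](C)(C)C(C)(C)C)O[C@@H](n1cc(C)c(=O)n(C)c1=O)[C@@H]2O[Si](C)(C)C(C)(C)C`, 5020 nM
compound 2, `Cc1cn([C@@H]2O[C@@H]3COC4(O)CS(=O)(=O)O[C@@]34[C@H]2O[Si](C)(C)C(C)(C)C)c(=O)[nH]c1=O`, 100000 nM

In a functional assay on CCRF-CEM cells (Homo sapiens) (on this read-out lower numbers stand for higher toxicity in this test and higher numbers for lower toxicity in this test), compound 1 gives the lower of the two numbers seen so far, and the number for compound 2 lies beyond the scatter above it. Compound 3, `Cc1cn([C@@H]2O[C@H](CO[Si](C)(C)C(C)(C)C)[C@@]3(OS(=O)(=O)C=C3NCCC(=O)OCc3ccccc3)[C@H]2O[Si](C)(C)C(C)(C)C)c(=O)n(C)c1=O`, has not yet been measured. It differs from compound 1 in one place: 2-(benzyloxycarbonyl)ethyl in place of ((ethoxycarbonyl)methyl)carbamoyl on an amine nitrogen. For the measured compounds named here, no measured pair differing in just one place is available, so the size of this step has no precedent among the known numbers. The expectation is for a step from compound 1 to compound 3 that stays within the scatter or reaches only a little beyond it, with no clear direction, namely a 1.0-fold lower number from compound 1 to compound 3 (0.00 log units; within the scatter). In this assay compound 3 is therefore expected to give about 5000 nM, with a likely range from 1500 nM to 20000 nM.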

Compound 3, half-maximal cytotoxic concentration: > 250000 nM
Compound 3 ended at the assay's limit; the forecaster's own chance of this, stated with the estimate: 15%; at least 50-fold (1.69 log units) between middle value and limit.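

In this assay, the amine nitrogen proves to be a place where the arm matters greatly: 2-(benzyloxycarbonyl)ethyl in place of ((ethoxycarbonyl)methyl)carbamoyl gives an at least 49-fold higher number from compound 1 to compound 3 (1.69 log units; beyond the scatter). Compound 3 gives > 250000 nM, which is a limit of the assay and not a number. The toxicity seen for compound 1 therefore depends on what sits on this nitrogen, and the step can be read only as a minimum: the limit of > 250000 nM in this assay, at which 1 of the 3 values shown sits.

Going by these compounds, the whole arm changes in this one step, and it stays open whether the urea, the ester or the benzyl ring accounts for the difference. Also open, on these data alone, is how a carboxylic acid in place of the ester, or a bare amine on this nitrogen, would read in this assay.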